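The source may hold more compounds than are shown below. What is called first, only, known or untested is meant among the compounds shown, and "the series" means these compounds.

Measured in an assay on isolated protein for inhibition of glutathione S-transferase P (Homo sapiens), with a stated time of 10 min; on this read-out higher numbers stand for weaker inhibition and lower numbers for stronger inhibition:
- compound 1, `O=C(O)CCC(=O)OCCCCCCSc1ccc([N+](=O)[O-])c2nonc12`: 530 nM
- compound 2, `O=C(CCC(=O)OCCCCCCSc1ccc([N+](=O)[O-])c2nonc12)Nc1ccccc1Cl`: 15500 nM

Within the data shown here, compound 2 stands highest of the two numbers in this assay; its only neighbour is compound 1. Among the measured compounds shown here, the single step between the two, a 29-fold higher number from compound 1 to compound 2 (1.47 log units; beyond the scatter), comes from (2-chlorophenyl)amino in place of hydroxy on a carbonyl carbon.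

Compound 3, `Cc1ccccc1NC(=O)CCC(=O)OCCCCCCSc1ccc([N+](=O)[O-])c2nonc12`, is not yet measured. Relative to compound 2 the change is methyl in place of chloro on an aromatic carbon. For the measured compounds named here, no measured step bears on this change: the one step available concerns the carbonyl substituent, not the aromatic ring of the anilide, so there is nothing to set a direction. Given a one-atom exchange at the same place, a step of a 1.0-fold lower number from compound 2 to compound 3 (0.01 log units; within the scatter) is expected, that is, no movement beyond the usual scatter. Compound 3 is therefore estimated at 15000 nM, with a range of 6000 nM to 40000 nM.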

Compound 3, half-maximal inhibitory concentration: 4100 nM
Compound 3: middle estimate off by 3.7-fold (0.56 log units), on the high side, outside the stated range (below it).
By their numbers in this assay, from the lowest: compound 1; then compound 3; then compound 2.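

In this assay this place on the six-membered aromatic ring is not silent: the exchange of chloro for methyl, with the same heavy-atom count and no hydrogen-bond donors or acceptors on either side, gives a 3.8-fold lower number from compound 2 to compound 3 (0.58 log units; beyond the scatter). The cost of putting an arylamino group in place of hydroxy on the carbonyl carbon therefore depends on the group carried by that ring, and with (2-methylphenyl)amino it is a 7.7-fold higher number from compound 1 to compound 3 (0.89 log units; beyond the scatter), so this amide still does not reach the number of the free acid. Nothing measured here accounts for the gap between methyl and chloro.

Still open, going by these compounds, is how other groups on the same aromatic carbon behave, such as fluoro, methoxy or plain hydrogen. Also open, on these data alone, is whether a simple amino group on the carbonyl carbon would stay closer to the free acid than the arylamino groups do.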